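The source may report more compounds than this note shows. Statements on the series, on what has been measured and on what is new or still open speak of the compounds shown alone.

Compound 1 `Cc1ccccc1CN1CCc2c(sc(NC(=O)c3ccccc3Cl)c2C(N)=O)C1` was tested in a functional assay on HL-60 cells (Homo sapiens) for antiproliferative activity, with a stated time of 24 h; on this read-out lower numbers stand for stronger inhibition and higher numbers for weaker inhibition. In this assay compound 1 returns only > 50000 nM, which is a limit of the assay and not a number. For the measured compounds named here, compound 2 `NC(=O)c1c(NC(=O)c2ccccc2Cl)sc2c1CCN(Cc1ccccc1F)C2` gives 21800 nM in this assay, and the step of an at least 2.2-fold lower number from compound 1 to compound 2 (0.36 log units; beyond the scatter) is the only measured step between the two. Compound 2 therefore holds the only number shown; the other value rests at the limit of > 50000 nM in this assay, at which 1 of the 2 values shown sits. Compound 3 `NC(=O)c1c(NC(=O)c2ccccc2Cl)sc2c1CCN(C(=S)Nc1ccccc1)C2` differs from compound 2 by a group of 9 heavy atoms (7 carbon, 1 nitrogen, 1 sulfur; one six-membered aromatic ring of carbon only) in place of a group of 8 heavy atoms (7 carbon, 1 fluorine; one six-membered aromatic ring of carbon only), on an amine nitrogen in a ring. Going by the values given here, the single measured step concerned a fluoro in place of a methyl on an aromatic carbon and does not touch the amine nitrogen in the ring, so it offers no guide to the direction of this change; the step of a 1.0-fold higher number from compound 2 to compound 3 (0.00 log units; within the scatter) is expected to stay within the scatter. Compound 3 is accordingly estimated at 22000 nM, within a range from 6000 nM to 50000 nM.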

Compound 3, half-maximal inhibitory concentration: 5940 nM
Estimate against measurement, compound 3: 3.7-fold (0.57 log units) above; measured number outside the range, below it.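

At the amine nitrogen in the ring, replacing 2-fluorobenzyl with the group of compound 3, which brings a double bond outside aromatic rings, a hydrogen-bond donor and a hydrogen-bond acceptor, gives a 3.7-fold lower number from compound 2 to compound 3 (0.56 log units; beyond the scatter) in this assay. The earlier step changed only a substituent on an aromatic carbon, whereas this one shows that replacing the whole group on the ring nitrogen also moves the read-out beyond the scatter, and the comparison with the methyl-bearing group gives an at least 8.4-fold lower number from compound 1 to compound 3 (0.92 log units; beyond the scatter). Compound 1 stands at a limit of the assay and not at a number, so that second step is only a bound: the limit of > 50000 nM in this assay, at which 1 of the 3 values shown sits.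

On these data alone, the sulfur, the nitrogen hydrogen and the changed link to the aromatic ring all change together in this step, so their separate shares stay open. The compounds shown also leave open how a carbonyl in place of the thiocarbonyl, or a longer chain before the aromatic ring, would read.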